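Adding a methoxy to compound 1: expecting compound 4

The compounds below may be only part of what the source reports. "The series", "measured", "known", "first", "only" and "open" are said of these compounds alone.

Measured in a functional assay on the whole organism (strain Sprague-Dawley) for inhibition, with Rattus norvegicus as the target, with a stated time of 10 min; a higher number here means that more compound is needed for the effect, a lower number that less compound is needed:
Compound 1 `O=C(O)c1cnc(-c2ccccc2)[nH]c1=O`: 50 mg/kg
Compound 2 `O=C(O)c1cnc(-c2ccccc2[N+](=O)[O-])[nH]c1=O`: > 50 mg/kg (a limit, not a number)
Compound 3 `COc1ccccc1-c1ncc(C(=O)O)c(=O)[nH]1`: 10 mg/kg

Of the two true numbers in this assay, compound 1 holds the higher, and compound 3 is its nearest neighbour. Compound 2 gives only a limit.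

Compound 4 `COc1cccc(-c2ncc(C(=O)O)c(=O)[nH]2)c1` is not yet measured. It differs from compound 1 by methoxy in place of hydrogen on an aromatic carbon, which is methoxy in place of hydrogen on an aromatic carbon, meta to a large group.

The closest guide is the same exchange in another place on that ring, seen in the step of a 5.0-fold lower number from compound 1 to compound 3 (0.70 log units; beyond the scatter) of modest size. The nitro step a number no lower from compound 1 to compound 2 (the limit leaves the size open) gives no readable size, and the step of an at least 5.0-fold lower number from compound 2 to compound 3 (0.69 log units; beyond the scatter) exchanges one group for another, so both bear on compound 4 only weakly. With the methoxy placed differently, a smaller step in the same direction is expected, one that may stay within the scatter. The expected change is a 1.7-fold lower number from compound 1 to compound 4 (0.22 log units; within the scatter) and no more than that.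

For compound 4 the estimate is 30 mg/kg in this assay with 10 mg/kg to 80 mg/kg as its expected range.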

Compound 4, dose for 50% inhibition: 10 mg/kg
Beside the measured number, compound 4's estimate is 3.0-fold (0.48 log units) above it, within the range that was stated.
By their numbers in this assay, from the lowest: compounds 3 and 4 (each within the scatter of the next); then compound 1.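

Methoxy in place of hydrogen, meta to a large group, is not a silent exchange: it gives a 5.0-fold lower number from compound 1 to compound 4 (0.70 log units; beyond the scatter) in this assay. Among these compounds, until now, a lower number from this exchange had been seen at only one place on the ring, whereas compound 3 with 10 mg/kg and compound 4 with 10 mg/kg now print the same value, so moving the methoxy between these two places shows no difference in this assay. Nothing shown here accounts for the step.

The compounds shown leave open whether this place needs methoxy itself or would accept another group, such as a hydroxyl, an amine or a longer chain. They also leave open how the methoxy would behave at any other place on the ring.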